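The source may hold more compounds than are shown below. What is called first, only, known or untested is meant among the compounds shown, and "the series" means these compounds.

Measured compounds:
compound 1 `CC(C)(C)c1cc(NC(=O)c2ccc(Cl)cc2Cl)ccc1O` with 13600 nM in an assay on isolated protein for antagonist activity at Bile acid receptor (Homo sapiens), read by HTRF, with a stated time of 30 min; on this read-out lower numbers stand for stronger inhibition and higher numbers for weaker inhibition
compound 2 `CC(C)c1cc(NC(=O)c2ccc(Cl)cc2Cl)ccc1O` with > 100000 nM in this assay
compound 3 `CCc1cc(NC(=O)c2ccc(Cl)cc2Cl)ccc1O` with > 100000 nM in this assay

Compound 3 gives only a limit in this assay and no number; compound 2 sits at the same limit, so the two cannot be ordered against each other. Going by the values given here, compound 1 is the only member of the series with a numerical value, and the steps of an at least 7.3-fold higher number from compound 1 to compound 2 (0.86 log units; beyond the scatter) and an at least 7.3-fold higher number from compound 1 to compound 3 (0.86 log units; beyond the scatter) both run toward weaker inhibition as the tert-butyl on the aromatic carbon is cut down. The step that the two limits leave unreadable from compound 2 to compound 3 is not readable, since both of its compounds sit at the limit of > 100000 nM in this assay, at which 2 of the 3 values shown sit.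

Compound 4 `Cc1cc(NC(=O)c2ccc(Cl)cc2Cl)ccc1O` carries the change (hydrogen in place of methyl on a saturated chain carbon bound to an aromatic carbon), which is the same direction of trimming that already took compound 1 to compound 2 and to compound 3. The two readable steps argue against any return to measurable inhibition, and nothing in the series points the other way. In this assay compound 4 is therefore expected to stay at or beyond the limit, with the step that the limit leaves unreadable from compound 3 to compound 4 estimated as essentially flat. The estimate for compound 4 is 150000 nM, within 50000 nM to 500000 nM, and most likely reported as a limit only.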

Compound 4, half-maximal inhibitory concentration: > 100000 nM
Compound 4: no number, only a limit; the forecaster's own chance of this, stated with the estimate: 85%; the middle value does not contradict the limit.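

In this assay compound 4 gives > 100000 nM and this is a limit, not a number. The methyl group on the aromatic carbon brings no return of measurable inhibition, and the comparison with the only numerical value in the series gives an at least 7.3-fold higher number from compound 1 to compound 4 (0.86 log units; beyond the scatter) and thus extends what isopropyl and ethyl already showed to the smallest alkyl group in the set, leaving tert-butyl as the only group shown here with a measurable value. The steps among compound 2, compound 3 and compound 4 cannot be read, so isopropyl, ethyl and methyl cannot be ordered, and the series now rests largely on one limit: the limit of > 100000 nM in this assay, at which 3 of the 4 values shown sit.

Still open, as far as these compounds go, is whether a group larger than tert-butyl on the same aromatic carbon, such as cyclohexyl or adamantyl, would carry inhibition beyond that of compound 1. Also open, from the compounds shown here alone, is whether a branched group holding a polar atom, such as a dimethylamine or a carboxylic acid on a quaternary carbon, would keep any of the measurable inhibition seen with tert-butyl.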